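This account rests on a few compounds, and the source may have more. Where it says the series, first, only, none or still open, it means among the compounds named here.

Measured compounds: compound 1 `Nc1ccc(C(=O)NN=C(c2ccccn2)c2ccccn2)cc1` with 7640 nM in an ADME assay on cells (Homo sapiens) for antiproliferative activity, read by MTT assay; a higher number here means a weaker inhibitor, a lower number a stronger inhibitor; compound 2 `O=C(NN=C(c1ccccn1)c1ccccn1)c1ccccc1` with 3040 nM.

Compound 2 gives the lowest of the two numbers; its nearest neighbour is compound 1, separated by a 2.5-fold lower number from compound 1 to compound 2 (0.40 log units; beyond the scatter). Compound 3 `O=C(NN=C(c1ccccn1)c1ccccn1)c1ccc(O)cc1` differs from compound 2 by hydroxy in place of hydrogen on an aromatic carbon. Only the step from compound 1 to compound 2 bears on this change, where removing a para substituent of the same kind lowered the number modestly, so adding one is expected to raise it modestly, shown as a 1.5-fold higher number from compound 2 to compound 3 (0.17 log units; within the scatter). Compound 3 is thus estimated at 4500 nM, ranging from 2000 nM to 10000 nM.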

Compound 3, half-maximal inhibitory concentration: 7530 nM
Compound 3: middle estimate off by 1.7-fold (0.22 log units), on the low side, within the range that was stated.
By their numbers in this assay, from the lowest: compound 2; then compounds 3 and 1 (each within the scatter of the next).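

In this assay, hydroxy on the aromatic carbon para to a large group gives a 2.5-fold higher number from compound 2 to compound 3 (0.39 log units; beyond the scatter) and leaves the phenyl of compound 2 with the lowest number of the three. Hydroxy in place of amino at this same place gives a 1.0-fold lower number from compound 1 to compound 3 (0.01 log units; within the scatter) and so does not separate the two groups, while both stand apart from hydrogen. Nothing shown gives a reason for this. The compounds shown leave open whether a methyl group, a fluorine atom or a carboxylic acid at this place would also raise the number.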